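Moving and Capping the Carbamoyl Group on the Benzyl Arm

A few compounds are considered here, and "the series" means these few. Any claim that something is new, unique, unknown or untested is made for them only; others in the source may bear on it.

Of the compounds shown here, three that share one core have been measured in a functional assay on MIA PaCa-2 cells (Homo sapiens) for antiproliferative activity, read by MTT assay, with a stated time of 72 h; a higher number here means that more compound is needed for the effect, a lower number that less compound is needed. Compound 1 `Cc1nn(Cc2ccccc2)c(C)c1NC(=O)c1ccc(COc2ccccc2)cc1` carries a plain benzyl group on the ring nitrogen and gives 10000 nM. Compound 3 `Cc1nn(Cc2ccccc2C(N)=O)c(C)c1NC(=O)c1ccc(COc2ccccc2)cc1` adds a carbamoyl group to that benzyl ring and gives 42000 nM, the highest of the two numbers recorded, with compound 1 as its nearest neighbour. Compound 2 `Cc1nn(Cc2ccc(C(N)=O)cc2)c(C)c1NC(=O)c1ccc(COc2ccccc2)cc1` is reported only as a limit of the assay, > 100000 nM.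

The step to compound 4 `Cc1nn(Cc2cccc(C(=O)N(C)C)c2)c(C)c1NC(=O)c1ccc(COc2ccccc2)cc1` reshapes the benzyl arm once more: 3-(dimethylcarbamoyl)phenyl in place of 2-carbamoylphenyl on a saturated chain carbon bound to an aromatic nitrogen. For the measured compounds named here, three measured steps bear on it. Adding a carbamoyl group cost potency in both places tried, an at least 10-fold higher number from compound 1 to compound 2 (1.00 log units; beyond the scatter) and a 4.2-fold higher number from compound 1 to compound 3 (0.62 log units; beyond the scatter), while shifting it from one of those places to the other gave an at least 2.3-fold lower number from compound 2 to compound 3 (0.37 log units; beyond the scatter). As far as these compounds go, nothing measured speaks to the methyl groups on the amide nitrogen, and the third position of the ring is untested. Every carbamoyl variant so far has sat at or above the number for compound 1, so compound 4 is expected to remain in that weaker range, with a step of about a 1.1-fold higher number from compound 3 to compound 4 (0.03 log units; within the scatter). Compound 4 is therefore estimated at 45000 nM, within 12000 nM to 150000 nM.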

Compound 4, half-maximal effective concentration: 6400 nM
Compound 4: middle estimate off by 7.0-fold (0.85 log units), on the high side; measured number below the stated range.
By their numbers in this assay, from the lowest: compounds 4 and 1 (each within the scatter of the next); then compound 3. At a limit, above all of these: compound 2.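

The benzyl ring can therefore carry an amide without the loss seen with compounds 2 and 3: moving to the 3-(dimethylcarbamoyl)phenyl group gives a clear gain over the 2-carbamoylphenyl group (a 6.6-fold lower number from compound 3 to compound 4 (0.82 log units; beyond the scatter)). Set against the plain benzyl group, the new group cannot be told apart in this assay (a 1.6-fold lower number from compound 1 to compound 4 (0.19 log units; within the scatter)), so here the dimethylcarbamoyl group neither helps nor harms within the scatter. The comparison with the 4-carbamoylphenyl group also points the same way (an at least 15-fold lower number from compound 2 to compound 4 (1.19 log units; beyond the scatter)), but it rests on a limit and not on a number: (the limit of > 100000 nM in this assay, at which 1 of the 4 values shown sits).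

Compound 4 differs from compounds 2 and 3 both in where the amide sits on the ring and in the two methyl groups on its nitrogen, and the compounds shown do not separate these two changes. Also open, as far as these compounds go, is whether a 3-carbamoylphenyl group, a morpholine amide or a carboxylic acid on the same ring would match compound 4 or would bring the number below that of compound 1.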